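A few compounds are considered here, and "the series" means these few. Any claim that something is new, unique, unknown or untested is made for them only; others in the source may bear on it.

In a functional assay on SK-BR-3 cells (Homo sapiens) for cytotoxicity, with a stated time of 24 h (on this read-out higher numbers stand for weaker inhibition and lower numbers for stronger inhibition), compound 1 `COc1cc(Cc2nc3c(N)ncnc3n2CCCC#CCNCCCCNCC#CCCCn2c(Cc3cc(OC)c(OC)c(OC)c3)nc3c(N)ncnc32)cc(OC)c1OC` reads > 100000 nM, which is a limit of the assay and not a number. Among the measured compounds shown here, compound 2 `C#CCCCn1c(Cc2cc(OC)c(OC)c(OC)c2)nc2c(N)ncnc21` gives 31800 nM, the only actual number so far, so it has no numerical neighbour to be ranked against. Compound 3 `COc1cc(Cc2nc3c(N)ncnc3n2CCCC#CCO)cc(OC)c1OC` follows from compound 2 through (hydroxymethyl in place of hydrogen on a triple-bonded carbon), with hydroxymethyl in place of hydrogen on a triple-bonded carbon. For the measured compounds named here, no measured step shows what such a change does, so the expectation rests on compound 2 at 31800 nM alone. In this assay the expected 1.1-fold higher number from compound 2 to compound 3 (0.04 log units; within the scatter) is small, leaning slightly toward weaker inhibition and not expected to go beyond the usual scatter. For compound 3 the estimate is 35000 nM, with an expected range of 12000 nM to 90000 nM.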

Compound 3, half-maximal inhibitory concentration: > 100000 nM
Compound 3: no number, only a limit (the forecaster's own chance of this, stated with the estimate: 15%); middle value at least 2.8-fold (0.45 log units) away from the limit.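

In this assay, among the compounds shown here, hydroxymethyl in place of hydrogen on a triple-bonded carbon is the first change that can be read as a step, and it gives an at least 3.1-fold higher number from compound 2 to compound 3 (0.49 log units; beyond the scatter) toward weaker inhibition. Compound 3 reads > 100000 nM, which is a limit of the assay and not a number. The step therefore sets only a lower bound on the loss, and its full size stays unresolved with so much of the series at the limit: the limit of > 100000 nM in this assay, at which 2 of the 3 values shown sit.

Going by these compounds, whether the loss belongs to hydroxymethyl itself or to any group on this triple-bonded carbon stays open. A methyl, an aminomethyl or a carboxylic acid in the same place would separate these two readings, and a longer hydroxyalkyl chain would test the distance of the hydroxyl.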